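A hydroxyl replaces the vinyl end of compound 2

This account rests on a few compounds, and the source may have more. Where it says the series, first, only, none or still open, it means among the compounds named here.

Among the measured compounds shown here, compound 2 `C=CCCCCOc1ccc2c(=O)c(-c3ccc(O)cc3)coc2c1` is the only compound here with a number rather than a limit: in an assay (Cricetulus griseus) for inhibition of Monoamine oxidase (Homo sapiens) (a higher number here means a weaker inhibitor, a lower number a stronger inhibitor), compound 2 gives 5000 nM. Compound 1 `CCOC(=O)CCCCOc1ccc2c(=O)c(-c3ccc(O)cc3)coc2c1` carries ethoxycarbonyl where compound 2 carries vinyl. In this assay compound 1 gives > 9000 nM, which is a limit of the assay and not a number (the limit of > 9000 nM in this assay, at which 1 of the 2 values shown sits). For the measured compounds named here, the only measured step is an at least 1.8-fold lower number from compound 1 to compound 2 (0.25 log units; that floor lies within the scatter). Compound 3 `O=c1c(-c2ccc(O)cc2)coc2cc(OCCCCCCO)ccc12` is not yet measured and differs from compound 2 as 2-hydroxyethyl in place of vinyl on a saturated chain carbon, four bonds along the chain from an oxygen on an aromatic ring. Since that single step has its floor within the scatter, the estimate for compound 3 is a step of no change at the digits printed from compound 2 to compound 3 (within the scatter). Compound 3 is therefore expected to give 5000 nM, between 1800 nM and 14000 nM.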

Compound 3, half-maximal inhibitory concentration: > 9000 nM
Compound 3: only a limit was reported (the forecaster's own chance of this, stated with the estimate: 25%); middle value at least 1.8-fold (0.25 log units) away from the limit.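

In this assay, a 2-hydroxyethyl group in place of vinyl on the chain gives an at least 1.8-fold higher number from compound 2 to compound 3 (0.25 log units; that floor lies within the scatter). Compound 3 gives only a limit of the assay, not a number: the limit of > 9000 nM in this assay, at which 2 of the 3 values shown sit. So a hydroxyl end joins the ethoxycarbonyl end in giving no number, while the step from compound 1 to compound 3 cannot be read.

As far as these compounds go, how large the true change from vinyl to 2-hydroxyethyl is, if there is one, stays open. So does whether an amine or a carboxylic acid at the chain end, or a longer chain, would give a lower number than compound 2.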